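Removing the Isobutyl Group: Cytotoxicity in BaF3 Cells

A few compounds are considered here, and "the series" means these few. Any claim that something is new, unique, unknown or untested is made for them only; others in the source may bear on it.

Compound 1 `CC(C)Cn1cc(-c2cc(Nc3ccc(OC(F)(F)F)cc3)ncn2)cn1` was tested in an ADME assay on BaF3 cells (Mus musculus) for cytotoxicity (on this read-out higher numbers stand for an effect only at larger amounts of compound and lower numbers for an effect already at smaller amounts), and gave > 10000 nM, which is a limit of the assay rather than a number. Two other compounds were measured in the same way. Compound 2 `CCNC(=O)c1cc2c(Nc3ccc(OC(F)(F)F)cc3)ncnc2s1` gives > 10000 nM in this assay, again a limit. Compound 3 `FC(F)(F)Oc1ccc(Nc2ncnc3nn(C4CCCCC4)cc23)cc1` gives > 10000 nM in this assay, also a limit. Where compound 1 stands among these values can therefore only be said through (the limit of > 10000 nM in this assay, at which 3 of the 3 values shown sit); none of the three measurements reaches a number, so no step between measured compounds can be given. Compound 4 `FC(F)(F)Oc1ccc(Nc2cc(-c3cn[nH]c3)ncn2)cc1` has not yet been measured in this assay. It differs from compound 1 by hydrogen in place of isobutyl on an aromatic nitrogen. Since all three measured compounds sit at the same limit in this assay, no step beyond the usual scatter is expected in either direction, and the most likely outcome for compound 4 is expected to be another limit. Compound 4 is estimated at 15000 nM, within 7000 nM to 40000 nM, in this assay. The implied step is expected to be a step that the limit leaves unreadable from compound 1 to compound 4.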

Compound 4, half-maximal effective concentration: > 10000 nM
Compound 4 gave a limit, no number; the forecaster's own chance of this, stated with the estimate: 85%; the middle value lies beyond the limit too.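

Compound 1 and compound 4 both stand at a limit rather than a number in this assay, so no step between them can be read: the limit of > 10000 nM in this assay, at which 4 of the 4 values shown sit.

The compounds shown leave open where any of them would show an effect, and whether hydrogen in place of isobutyl shifts that concentration at all.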